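The source may hold more compounds than are shown below. What is called first, only, known or untested is meant among the compounds shown, and "the series" means these compounds.

Measured compounds:
compound 1 `CC(C)OC(=O)N1CCC(Oc2ncnc3c2CCN3c2ccc(S(C)(=O)=O)cc2F)CC1` — 50.1 nM
compound 2 `CC(C)OC(=O)N1CCC(Oc2cccc3c2CCN3c2ccc(S(C)(=O)=O)cc2F)CC1` — 1000 nM

In a functional assay on CHO-K1 cells for agonist activity at Glucose-dependent insulinotropic receptor (Homo sapiens), read by a luciferase reporter, with a stated time of 5 h (a higher number here means that more compound is needed for the effect, a lower number that less compound is needed), compound 1 gives the lower of the two numbers; compound 2 sits at a far higher value, a gap well beyond the usual scatter of this assay. The two differ in the shared core, and no counted difference between them is recorded here, so only the two values themselves are noted.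

Compound 3 `COCCOC(=O)N1CCC(Oc2ncnc3c2CCN3c2ccc(S(C)(=O)=O)cc2F)CC1` is not yet measured. Against compound 1 it carries 2-methoxyethyl in place of isopropyl on an oxygen next to a carbonyl group. Among the measured compounds shown here, there is no measured pair that isolates this change, so its effect is open; the group that enters is of similar size and adds one hydrogen-bond acceptor, and a small shift toward a higher number, or none beyond the scatter, is expected, with a 2.4-fold higher number from compound 1 to compound 3 (0.38 log units; beyond the scatter) as the expected step. For compound 3 the value in this assay is estimated at 120 nM, with a range from 40 nM to 400 nM.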

Compound 3, half-maximal effective concentration: 316 nM
For compound 3 the middle estimate is 2.6-fold (0.42 log units) below the measured one, and the stated range covers the measured number.
By their numbers in this assay, from the lowest: compound 1; then compound 3; then compound 2.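

In this assay, among the compounds shown here, 2-methoxyethyl in place of isopropyl on an oxygen next to a carbonyl group gives a 6.3-fold higher number from compound 1 to compound 3 (0.80 log units; beyond the scatter), the first reading of this position. The position therefore responds to what it carries, even though the exchange is limited to a single chain that enters with one hydrogen-bond acceptor and no ring, donor or net charge. No supporting data bear on the reason for this step.

For the compounds shown here, the single step changes the chain's branching and adds its oxygen together, so the contribution of each remains unresolved; an unbranched butyl chain or a branched chain containing an ether oxygen would separate them. On these data alone, whether the step carries over to the core of compound 2 also remains open.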